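Working notes: replacing quinolin-3-yl with pyridin-4-yl

The source may report more compounds than this note shows. Statements on the series, on what has been measured and on what is new or still open speak of the compounds shown alone.

Values so far in a physicochemical assay for lipophilicity; on this read-out higher numbers stand for higher lipophilicity and lower numbers for lower lipophilicity:
- compound 1 `CN(C)c1ccc(C(=O)OCC2(CO)C/C(=C\c3cnc4ccccc4c3)C(=O)O2)cc1`: 3.22
- compound 2 `CC(C)CC(CC(C)C)C(=O)OCC1(CO)C/C(=C\c2ccccn2)C(=O)O1`: 3.79
- compound 3 `CN(C)c1ccc(C(=O)OCC2(CO)C/C(=C/c3cnc4ccccc4c3)C(=O)O2)cc1`: 3.22

Compound 1 stands level with compound 3, and together they are the lowest of the three. Compound 2 is higher, beyond the scatter. Compound 4 `CN(C)c1ccc(C(=O)OCC2(CO)C/C(=C\c3ccncc3)C(=O)O2)cc1` differs from compound 1 as follows: pyridin-4-yl in place of quinolin-3-yl on a double-bonded chain carbon bound to a double-bonded ring carbon. Among the measured compounds shown here, the only measured step, no change at the digits printed from compound 1 to compound 3 (within the scatter), concerns how the double bond is drawn and leaves quinolin-3-yl in place, so it sets no size for this change. The expectation starts from compound 1 at 3.22 and rests on the loss of the aromatic ring of carbon only. The expected move in this assay is downward, estimated as a number 0.82 log units lower from compound 1 to compound 4 (beyond the scatter). Compound 4 is estimated at 2.4, with an expected range of 1.8 to 3.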

Compound 4, partition coefficient: 2.07
The estimate for compound 4 lay 0.33 log units above the measured number, within the range that was stated.
By their numbers in this assay, from the lowest: compound 4; then compounds 1 and 3 (each within the scatter of the next); then compound 2.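

In this assay, pyridin-4-yl in place of quinolin-3-yl on a double-bonded chain carbon bound to a double-bonded ring carbon gives a number 1.15 log units lower from compound 1 to compound 4 (beyond the scatter) and so puts a first measured size on a change of this group. The group at this place moves the number far more than the drawing of the double bond did, which made no change at the digits printed from compound 1 to compound 3 (within the scatter) and left quinolin-3-yl in place.

Still open, going by these compounds, is how a phenyl group, or a pyridin-4-yl carrying an amine, would read at this place. Also open, on these data alone, is whether the drawing of the double bond stays without effect with pyridin-4-yl in place.

Nothing at hand bears on the reason for the step with pyridin-4-yl.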